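The compounds below may be only part of what the source reports. "The series", "measured", "known", "first", "only" and "open" are said of these compounds alone.

Measured so far in a functional assay on DU-145 cells (Homo sapiens) for inhibition; a lower number here means a stronger inhibitor, a higher number a weaker inhibitor:
- compound 1 `Oc1ccc(-c2cc(-c3ccccc3F)cc(-c3ccccc3O)n2)cc1` gives > 50000 nM.
- compound 2 `Oc1ccc(-c2cc(-c3cccc(F)c3)cc(-c3ccccc3O)n2)cc1` gives > 50000 nM.
- compound 3 `Oc1ccc(-c2cc(-c3ccccc3F)cc(-c3cccc(O)c3)n2)cc1` gives 3160 nM.

Compound 1 has a value that is a limit of the assay, not a number. Compound 2 has a value that is likewise a limit, (the limit of > 50000 nM in this assay, at which 2 of the 3 values shown sit). Compound 3 alone gives a number. The change from compound 1 to compound 3 produces an at least 15-fold lower number from compound 1 to compound 3 (1.19 log units; beyond the scatter). The change from compound 1 to compound 2, (3-fluorophenyl in place of 2-fluorophenyl on an aromatic carbon), gives a step that the two limits leave unreadable from compound 1 to compound 2, so its size is not readable.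

Compound 4 `Oc1ccc(-c2cc(-c3cccc(F)c3)cc(-c3cccc(O)c3)n2)cc1` is not yet measured. It differs from compound 3 by 3-fluorophenyl in place of 2-fluorophenyl on an aromatic carbon, the same kind of change as from compound 1 to compound 2, but around the place the groups differ: there it is meta to a 2-hydroxyphenyl group, here meta to a 3-hydroxyphenyl group. The two cores differ by 3-hydroxyphenyl in place of 2-hydroxyphenyl on an aromatic carbon.

For compound 4 in this assay a step of a 1.0-fold higher number from compound 3 to compound 4 (0.01 log units; within the scatter) is expected. Among the measured compounds shown here, this rests on compound 3 giving 3160 nM, the only number in the set, while the earlier step of the same kind has no readable size. The estimate for compound 4 is 3200 nM, expected between 1000 nM and 12000 nM.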

Compound 4, half-maximal inhibitory concentration: 2700 nM
Compound 4: the middle estimate sits 1.2-fold (0.07 log units) above what was measured, within the range that was stated.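

In this assay, 3-hydroxyphenyl in place of 2-hydroxyphenyl, carried to the core of compound 2, gives an at least 18-fold lower number from compound 2 to compound 4 (1.26 log units; beyond the scatter), and set beside the earlier step it reads: the same change on two cores in this assay, an at least 15-fold lower number (1.19 log units; beyond the scatter) from compound 1 to compound 3 and an at least 18-fold lower number (1.26 log units; beyond the scatter) from compound 2 to compound 4; the limit leaves it open whether they differ. Compound 1 and compound 2 each give a limit of the assay and not a number, so the lower number recurs on both cores shown, but the true size of neither step is known: the limit of > 50000 nM in this assay, at which 2 of the 4 values shown sit. On these data alone, with 3-hydroxyphenyl in the molecule, 3-fluorophenyl in place of 2-fluorophenyl gives a 1.2-fold lower number from compound 3 to compound 4 (0.07 log units; within the scatter), while the same exchange with 2-hydroxyphenyl in the molecule cannot be read, so it stays unknown whether the two fluorophenyl groups also match there.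

The compounds shown leave open how far the 3-hydroxyphenyl effect holds on cores carrying something other than a fluorophenyl group, such as a chlorophenyl or a methoxyphenyl group. They also leave open whether an amine or a carboxylic acid could stand in place of the hydroxyl group on that ring.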